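Trifluoromethyl in Place of Methyl: An Estimate

The compounds below may be only part of what the source reports. "The series", "measured", "known", "first", "only" and "open" are said of these compounds alone.

Compound 1, `Cc1c(C(=O)Nc2ccc(Oc3ccnc4[nH]ccc34)cc2)nnn1-c1ccccc1`: 7260 nM
Compound 2, `Cc1c(C(=O)Nc2ccc(Oc3ccnc4[nH]ccc34)cc2)nnn1-c1ccc(F)cc1`: 3450 nM

In a functional assay on PC-3 cells (Homo sapiens) for cytotoxicity, read by MTT assay, with a stated time of 72 h (a lower number here means a stronger inhibitor, a higher number a weaker inhibitor), compound 1 gives 7260 nM, while compound 2 gives 3450 nM. Going by the values given here, compound 2 therefore holds the lowest number of the two; its only neighbour is compound 1, and the single measured step between them is a 2.1-fold lower number from compound 1 to compound 2 (0.32 log units; beyond the scatter), a fluoro in place of hydrogen on an aromatic carbon of the outer phenyl group.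

Compound 3, `O=C(Nc1ccc(Oc2ccnc3[nH]ccc23)cc1)c1nnn(-c2ccc(F)cc2)c1C(F)(F)F`, has not yet been measured. It differs from compound 2 in one place: trifluoromethyl in place of methyl on an aromatic carbon. Among the compounds with values here, no measured step touches this position. Within the data shown here, the one step on record, a 2.1-fold lower number from compound 1 to compound 2 (0.32 log units; beyond the scatter), concerns a different group on a different ring, so it gives no direct guide to what a trifluoromethyl in place of methyl will do. With nothing closer to lean on, the expected step of a 1.4-fold lower number from compound 2 to compound 3 (0.14 log units; within the scatter) is modest and could fall either side of the scatter. Compound 3 is estimated at 2500 nM, with a range from 800 nM to 8000 nM.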

Compound 3, half-maximal inhibitory concentration: 2830 nM
Estimate against measurement, compound 3: 1.1-fold (0.05 log units) below; the measured number falls inside the stated range.
By their numbers in this assay, from the lowest: compounds 3 and 2 (each within the scatter of the next); then compound 1.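

In this assay, going by these compounds alone, the only step measured at this position, on an aromatic carbon of the five-membered aromatic ring with 3 nitrogen, is a 1.2-fold lower number from compound 2 to compound 3 (0.09 log units; within the scatter), so this pair does not separate trifluoromethyl from methyl. With the 4-fluorophenyl group held constant, a group of 4 heavy atoms thus takes the place of a group of 1 heavy atom with no change in the number beyond the usual scatter, which the step on the outer phenyl group could not have shown. This holds for this one pair and this one cell read-out only, and no measurement shown gives any reason for the result.

The compounds shown leave open whether a different group at the same position, such as a hydrogen, an amine, a hydroxyl or a longer chain like ethyl or propyl, would also stay within the scatter of compound 2 or would move the number clearly. They also leave open whether trifluoromethyl in place of methyl would give a similar step on compound 1, which carries an unsubstituted phenyl group in place of the 4-fluorophenyl group.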